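Aryl amine at the pyridine replaced by a saturated amine

The source may hold more compounds than are shown below. What is called first, only, known or untested is meant among the compounds shown, and "the series" means these compounds.

Measured compounds:
- compound 1, `CC(C(=O)NCc1ccc(C(F)(F)F)nc1NCC1CCN(C(=O)OC(C)(C)C)CC1)c1ccc(NS(C)(=O)=O)c(F)c1`: 1140 nM
- compound 2, `CC(C(=O)NCc1ccc(C(F)(F)F)nc1N(C)c1ccccc1)c1ccc(NS(C)(=O)=O)c(F)c1`: 57.4 nM
- compound 3, `C[C@H](C(=O)NCc1ccc(C(F)(F)F)nc1N1CCC[C@H]1CO)c1ccc(NS(C)(=O)=O)c(F)c1`: "not active" (no number reported)

In a functional assay on CHO-K1 cells for antagonist activity at transient receptor potential cation channel subfamily V member 1 (Homo sapiens), read by FLIPR (a lower number here means a stronger inhibitor, a higher number a weaker inhibitor), compound 2 gives 57.4 nM, the lowest of the two numbers in hand. The nearest number belongs to compound 1, which gives 1140 nM, a gap that lies beyond the scatter. Compound 3 gives "not active" (no number reported) in this assay and so supplies no number at all. Among the measured compounds shown here, no two of the three share a single point of difference, so no step between measured compounds can be stated.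

Compound 4, `CC(C(=O)NCc1ccc(C(F)(F)F)nc1N1CCC(CN(C)C)CC1)c1ccc(NS(C)(=O)=O)c(F)c1`, is the next candidate. Its change from compound 2 is 4-((dimethylamino)methyl)piperidin-1-yl in place of methyl(phenyl)amino on an aromatic carbon. Both compounds that carry a saturated nitrogen substituent at this position, compound 1 and compound 3, stand clearly weaker than compound 2 or give no number, while compound 2 alone carries the methyl(phenyl)amino group.

On that basis compound 4 is expected to be a weaker inhibitor than compound 2, with an expected step of a 26-fold higher number from compound 2 to compound 4 (1.42 log units; beyond the scatter) in this assay, beyond the scatter. The estimate for compound 4 is 1500 nM, in a range from 300 nM to 8000 nM, with a real chance that this assay returns no number for compound 4 at all, as it did for compound 3.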

Compound 4, half-maximal inhibitory concentration: 426 nM
For compound 4 the middle estimate is 3.5-fold (0.55 log units) above the measured one; the measured number falls inside the stated range.
By their numbers in this assay, from the lowest: compound 2; then compound 4; then compound 1.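

In this assay, 4-((dimethylamino)methyl)piperidin-1-yl in place of methyl(phenyl)amino, on the aromatic carbon next to the ring nitrogen, gives a 7.4-fold higher number from compound 2 to compound 4 (0.87 log units; beyond the scatter) and costs potency without removing a measurable number. This position therefore still gives a measurable number without the six-membered aromatic ring of carbon only, and compound 2 remains the lowest number in the series. The printed values also separate two compounds with non-aromatic groups at this position, with compound 4 at 426 nM and compound 1 at 1140 nM, so a non-aromatic ring here does not fix a single level of activity, although nothing measured here explains the step from compound 2.

As far as these compounds go, the exchange alters the ring and the dimethylaminomethyl side chain in one move, so the share of each in the step stays open. Plain piperidin-1-yl would address the ring alone, while morpholin-4-yl, or a phenyl ring bearing a dimethylaminomethyl chain, would show whether the side chain can be carried on other rings at this position.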